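The compounds below may be only part of what the source reports. "The series", "measured", "known", "first", "only" and "open" are said of these compounds alone.

Series notes. The shared core carries a sulfonamide nitrogen bearing an aryl group, and the measured compounds vary that aryl. Compound 1 `CCc1ccccc1N(Cc1nnc(Cc2ccc(OC)cc2)o1)S(=O)(=O)c1ccc(C)cc1` in a functional assay on CHO cells for antagonist activity at prostaglandin E2 receptor EP1 subtype (Homo sapiens), read by FLIPR and calcium flux (a lower number here means a stronger inhibitor, a higher number a weaker inhibitor), gives 631 nM. Compound 2 `COc1ccc(Cc2nnc(CN(c3cccc(C(F)(F)F)c3C)S(=O)(=O)c3ccc(C)cc3)o2)cc1` gives 398 nM, and compound 3 `COc1ccc(Cc2nnc(CN(c3cccc(Cl)c3Cl)S(=O)(=O)c3ccc(C)cc3)o2)cc1` gives 39.8 nM. The steps run as follows: a 1.6-fold lower number from compound 1 to compound 2 (0.20 log units; within the scatter); a 16-fold lower number from compound 1 to compound 3 (1.20 log units; beyond the scatter); a 10-fold lower number from compound 2 to compound 3 (1.00 log units; beyond the scatter). Compound 3 thus holds the lowest number of the three, with compound 2 nearest and compound 1 furthest, both gaps beyond the scatter.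

Compound 4 `COc1ccc(Cc2nnc(CN(c3cccc(Cl)c3Cl)S(=O)(=O)c3ccc(Cl)cc3)o2)cc1` alters a different part of the molecule: chloro in place of methyl on an aromatic carbon, read one bond further out as (4-methylphenyl)sulfonyl to (4-chlorophenyl)sulfonyl. Among the measured compounds shown here, no measured step touches this sulfonyl aryl; all three measured steps concern the aryl on the sulfonamide nitrogen, so none bears directly on this change. With nothing in the measured set to argue for a shift in either direction, the step of a 1.0-fold higher number from compound 3 to compound 4 (0.00 log units; within the scatter) is expected to lie within the scatter. Compound 4 is accordingly estimated at 40 nM, with a range from 13 nM to 130 nM.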

Compound 4, inhibition constant: 63.1 nM
Estimate against measurement, compound 4: 1.6-fold (0.20 log units) below; low and high end bracket the measured number.
By their numbers in this assay, from the lowest: compounds 3 and 4 (each within the scatter of the next); then compounds 2 and 1 (each within the scatter of the next).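

In this assay, among the compounds shown here, this is the first reading on the sulfonyl aryl, as all earlier steps concerned the aryl on the sulfonamide nitrogen: a 1.6-fold higher number from compound 3 to compound 4 (0.20 log units; within the scatter). With 2,3-dichlorophenyl held constant on that nitrogen, methyl is therefore not required at this position, para to a large group, and chloro in its place gives no change beyond the scatter. Nothing available speaks to the reason for this result.

Still open, from the compounds shown here alone, is whether other groups at this position, such as methoxy, a nitrile or a carboxylic acid, would read the same way, or whether a cyclohexyl in place of the whole 4-chlorophenyl would. Also open, going by these compounds, is whether the same exchange holds with the nitrogen aryl of compound 1 or compound 2.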